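This account rests on a few compounds, and the source may have more. Where it says the series, first, only, none or still open, it means among the compounds named here.

Measured in a functional assay on C6 cells (Rattus norvegicus) for cytotoxicity, read by MTT assay, with a stated time of 24 h, tested at 6 ug/mL; a lower number here means a stronger effect, a higher number a weaker effect of the compound at the concentration tested:
compound 1 `O=C(CSc1ncccn1)N/N=c1/scc(-c2ccc(Br)cc2)n1-c1ccccc1` gives 76.4%
compound 2 `Cn1cnnc1SCC(=O)N/N=c1/scc(-c2ccc(C#N)cc2)n1-c1ccccc1` gives 70.2%
compound 3 `Cn1nnnc1SCC(=O)N/N=c1/scc(-c2ccc([N+](=O)[O-])cc2)n1-c1ccccc1` gives 80.4%

All three numbers in this assay lie within the usual scatter of one another, so no order among them can be read. Compound 1 sits closest to compound 3 and furthest from compound 2, with both gaps inside the scatter, and all three show a weak effect at the concentration tested.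

Compound 4 `O=C(CSc1ncccn1)N/N=c1/scc(-c2ccc(Cl)cc2)n1-c1ccccc1` has not yet been measured in this assay. It differs from compound 1 in one place: chloro in place of bromo on an aromatic carbon. Going by the values given here, nothing among the measured compounds separates a halogen from another at this place, and the three measured numbers all sit in the same narrow band, so no step beyond the scatter is expected in this assay. Compound 4 is therefore estimated at 78%, between 65% and 90%, which means an expected step of a number 1.6 percentage points higher from compound 1 to compound 4 (within the scatter) of essentially nothing beyond the scatter.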

Compound 4, a percentage reported as activity, at one concentration (the size of the read-out at that concentration, not a potency): 95.9%
For compound 4 the middle estimate is 17.9 percentage points below the measured one, outside the stated range (above it).
By their numbers in this assay, from the lowest: compounds 2, 1 and 3 (each within the scatter of the next, the first and the last beyond it); then compound 4.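

In this assay, 4-bromophenyl to 4-chlorophenyl gives a number 19.5 percentage points higher from compound 1 to compound 4 (beyond the scatter), so the read-out at this place does respond to the choice of halogen, with the chloro compound showing the weaker effect. Going by these compounds alone, this single-atom exchange therefore carries a step beyond the scatter, which the earlier compounds, differing in more than one place, could not show. No available evidence accounts for the step.

Open, on these data alone, is whether a fluoro, a methoxy or an amino group on this aromatic carbon would read like compound 1 or like compound 4. Also open, as far as these compounds go, is whether the same exchange gives a similar step on other members.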